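A few compounds are considered here, and "the series" means these few. Any claim that something is new, unique, unknown or untested is made for them only; others in the source may bear on it.

Measured compounds in an ADME assay on HEK293 cells (Homo sapiens) for cytotoxicity, read by CellTiter-Glo and resazurin assay, with a stated time of 72 h; a higher number here means that more compound is needed for the effect, a lower number that less compound is needed:

Compound 1, `CCOC(=O)CCCCCOc1cccc(CN(C(=O)c2ccc(-c3cnc(OC)nc3OC)cc2)C(C)C)c1`, gives > 26000 nM, a limit of the assay rather than a number.
Compound 2, `CCOC(=O)CCCCCOc1cccc(CN(C(=O)c2ccc(-c3cccc(OC(C)C)c3)cc2)C(C)C)c1`, gives > 26000 nM, again a limit.
Compound 3, `CCOC(=O)CCCCCOc1cccc(CN(C(=O)c2ccc(-c3ccc(Cl)c(Cl)c3)cc2)C(C)C)c1`, gives > 26000 nM, also a limit.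

Compound 3 therefore stands where the other two stand: at the upper limit of this assay, with no numerical value resolved for any of the three, as the limit of > 26000 nM in this assay, at which 3 of the 3 values shown sit, records. The three steps among the measured compounds, a step that the two limits leave unreadable from compound 1 to compound 2, a step that the two limits leave unreadable from compound 1 to compound 3 and a step that the two limits leave unreadable from compound 2 to compound 3, cannot be sized, since both ends of each sit at the same limit.

Compound 4, `CCOC(=O)CCCCCOc1cccc(CN(C(=O)c2ccc(Br)cc2)C(C)C)c1`, is not yet measured in this assay. It differs from compound 3 by bromo in place of 3,4-dichlorophenyl on an aromatic carbon. For the measured compounds named here, none of the measured steps gives a readable size that could be carried over to this change; what they show is only that three different groups at this position all left cytotoxicity beyond the limit. The step expected in this assay is therefore none beyond the scatter, with compound 4 anticipated to remain at the limit as well, and a step that the limit leaves unreadable from compound 3 to compound 4 is the estimated step. Compound 4 is expected to give about 40000 nM, within a range of 20000 nM to 120000 nM.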

Compound 4, half-maximal effective concentration: > 26000 nM
Compound 4: a limit, no number; the forecaster's own chance of this, stated with the estimate: 85%; the middle value lies beyond the limit too.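

In this assay compound 4 sits at the same limit as compound 1, compound 2 and compound 3, so none of the steps from those three compounds to compound 4 can be read: the limit of > 26000 nM in this assay, at which 4 of the 4 values shown sit. The compounds shown leave open how much of any of the four is needed for the effect, and whether any group at this position would bring a numerical value.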